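This account rests on a few compounds, and the source may have more. Where it says the series, first, only, none or still open, it means among the compounds named here.

Compound 3 `CN(C)C(=O)C(C)(C)COc1nnc(-c2ccc(NC(=O)c3ccc4ccccc4c3)cc2)n1C` gives 21.9 10^-6 cm/s in an ADME assay on Caco-2 cells (Homo sapiens) for permeability, in the apical to basolateral direction; on this read-out lower numbers stand for lower permeability and higher numbers for higher permeability. Compound 1 `Cn1c(OCC(C)(C)C(=O)Nc2ccccc2)nnc1-c1ccc(NC(=O)c2ccc3ccccc3c2)cc1` gives 19.8 10^-6 cm/s, and compound 2 `Cc1cc(NC(=O)c2ccc3ccccc3c2)ccc1-c1cnc(OCC(C)(C)C(=O)O)cn1` gives 19.3 10^-6 cm/s; all three numbers lie within the usual scatter of one another, so compound 3 stands level with both. Compound 4 `Cn1c(OCC(C)(C)C(N)=O)nnc1-c1ccc(NC(=O)c2ccc3ccccc3c2)cc1` differs from compound 3 by amino in place of dimethylamino on a carbonyl carbon. Among the compounds with values here, one measured step touches the same carbonyl carbon: a 1.1-fold higher number from compound 1 to compound 3 (0.04 log units; within the scatter), which shows that exchanging the group on that amide nitrogen left this read-out unchanged. Within the data shown here, no measured step covers a primary amide, and compound 4 is the only compound of that kind here. The expected step is therefore a 1.5-fold lower number from compound 3 to compound 4 (0.16 log units; within the scatter), with a slight lowering allowed for. Compound 4 is expected to give 15 10^-6 cm/s, between 7 10^-6 cm/s and 28 10^-6 cm/s.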

Compound 4, apparent permeability: 0.1 10^-6 cm/s
Compound 4: the middle estimate sits 150-fold (2.18 log units) above what was measured, outside the stated range (below it).
By their numbers in this assay, from the lowest: compound 4; then compounds 2, 1 and 3 (each within the scatter of the next).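

In this assay the group on this carbonyl carbon turns out to matter: amino in place of dimethylamino gives a 220-fold lower number from compound 3 to compound 4 (2.34 log units; beyond the scatter) and hydrogen in place of phenyl on the amide nitrogen gives a 200-fold lower number from compound 1 to compound 4 (2.30 log units; beyond the scatter) on the same core. Anilino and dimethylamino had stood level, so only the primary amide of compound 4 breaks from them. Nothing measured here bears on the reason for this fall. The compounds shown leave open whether methylamino, a single methyl on that nitrogen, would stand with compound 3 or with compound 4. They also leave open where a longer chain such as ethylamino would fall.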